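Estimating Compound 4 from a Halogenated Aryl Swap

The compounds below may be only part of what the source reports. "The series", "measured", "known", "first", "only" and "open" are said of these compounds alone.

Measured compounds:
compound 1, `CCNC(=O)c1cc(Oc2ccc(NC(=O)c3nn(-c4ccc(Br)cc4F)c(=O)cc3C)cc2)ccn1`: 35100 nM
compound 2, `CCCNC(=O)c1cc(Oc2ccc(NC(=O)c3nn(-c4ccc(C)cc4)c(=O)cc3C)cc2F)ccn1`: 34600 nM
compound 3, `CCNC(=O)c1cc(Oc2ccc(NC(=O)c3nn(-c4ccc(C)cc4)c(=O)cc3C)cc2)ccn1`: 51300 nM

Of the compounds shown here, three have been measured in a functional assay on MCF7 cells (Homo sapiens) for antiproliferative activity, read by MTT assay, with a stated time of 72 h (on this read-out higher numbers stand for weaker inhibition and lower numbers for stronger inhibition), and all three give numbers of similar magnitude. Compound 1 and compound 3 share one core and differ in one place only, described by 4-bromo-2-fluorophenyl in place of 4-methylphenyl on an aromatic nitrogen. The step that accompanies this swap is a 1.5-fold lower number from compound 3 to compound 1 (0.16 log units; within the scatter), a difference that does not stand out from the scatter of the assay.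

Compound 2 carries a core that differs from the core of compound 3 in more than one place, and the difference between the two cores is not broken down here. The values of compound 2 and compound 3 in this assay lie within the scatter of each other, so nothing about order can be drawn from them.

The unmeasured compound 4, `CCCNC(=O)c1cc(Oc2ccc(NC(=O)c3nn(-c4ccc(Br)cc4F)c(=O)cc3C)cc2F)ccn1`, is related to compound 2 by the same change that relates compound 1 to compound 3: 4-bromo-2-fluorophenyl in place of 4-methylphenyl on an aromatic nitrogen. The place lines of the two swaps match word for word, so the two changes are the same. Because the earlier swap gave a 1.5-fold lower number from compound 3 to compound 1 (0.16 log units; within the scatter), a step of comparable size is expected from compound 2 to compound 4, namely a 1.3-fold lower number from compound 2 to compound 4 (0.11 log units; within the scatter). On this basis compound 4 is estimated at 27000 nM in this assay, expected to fall between 12000 nM and 60000 nM.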

Compound 4, half-maximal inhibitory concentration: "not active" (no number reported)
No number was reported for compound 4; no gap can be computed for the estimate.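

Among the compounds shown here, compound 4 is recorded in this assay as not active, with no number reported, so no step from compound 2 to compound 4 can be read. Nothing in the data shown bears on this result. The compounds shown leave open whether 4-bromo-2-fluorophenyl in place of 4-methylphenyl has the same size of effect on the core of compound 2 as on the core of compound 3.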